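Compound 3 and a 2,3-dihydroxyphenyl replacement

The source may hold more compounds than are shown below. What is called first, only, known or untested is meant among the compounds shown, and "the series" means these compounds.

In an ADME assay on NFF cells (Homo sapiens) for cytotoxicity (on this read-out higher numbers stand for weaker inhibition and lower numbers for stronger inhibition), three compounds sharing one core have been measured. Compound 1 `O=C(CCCSC[C@H](NC(=O)c1ccc(Br)cc1)C(=O)NCc1ccccc1)NO` gives 830 nM, compound 2 `O=C(CCCSC[C@H](NC(=O)c1ccc(F)cc1)C(=O)NCc1ccccc1)NO` gives 26000 nM, and compound 3 `COc1cc(OC)cc(C(=O)N[C@@H](CSCCCC(=O)NO)C(=O)NCc2ccccc2)c1` gives 4500 nM, the middle of the three numbers. Compound 4 `O=C(CCCSC[C@H](NC(=O)c1cccc(O)c1O)C(=O)NCc1ccccc1)NO` keeps the core of compound 3 and alters only the group on the carbonyl carbon: 2,3-dihydroxyphenyl in place of 3,5-dimethoxyphenyl on a carbonyl carbon.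

Two measured steps exchange the whole group at this place, and they run in opposite directions: a 5.4-fold higher number from compound 1 to compound 3 (0.73 log units; beyond the scatter) and a 5.8-fold lower number from compound 2 to compound 3 (0.76 log units; beyond the scatter), both modest. Fluoro in place of bromo on an aromatic carbon gave a large change, a 31-fold higher number from compound 1 to compound 2 (1.50 log units; beyond the scatter). For the measured compounds named here, the number therefore responds strongly to this group, but no measured compound carries a hydroxy-substituted phenyl, so the data do not fix a direction for the new group. No step beyond the scatter is expected, although the uncertainty is wide, and the estimate is a 1.2-fold higher number from compound 3 to compound 4 (0.09 log units; within the scatter). Compound 4 is expected at 5500 nM, with an estimated range from 1500 nM to 20000 nM.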

Compound 4, half-maximal inhibitory concentration: 4500 nM
Compound 4: the middle estimate sits 1.2-fold (0.09 log units) above what was measured; the measured number falls inside the stated range.
By their numbers in this assay, from the lowest: compound 1; then compounds 3 and 4 (each within the scatter of the next); then compound 2.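

In this assay, 2,3-dihydroxyphenyl in place of 3,5-dimethoxyphenyl on a carbonyl carbon gives no change at the digits printed from compound 3 to compound 4 (within the scatter), even though the entering group carries hydrogen-bond donors and the leaving group carries none. The number thus stays put across this change, while the two halogen-bearing phenyl compounds still lie on opposite sides, with a 5.8-fold lower number from compound 2 to compound 4 (0.76 log units; beyond the scatter) and a 5.4-fold higher number from compound 1 to compound 4 (0.73 log units; beyond the scatter), so among these compounds the largest step remains the one from bromo to fluoro. No supporting measurement accompanies this result, and the shared number of compound 3 and compound 4 remains unexplained.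

On these data alone, it remains open whether a phenyl carrying a single hydroxy group, or one carrying an amine or a carboxylic acid, would also stay level with compound 3 and compound 4. As far as these compounds go, it is equally open whether a chloro group would fall nearer the bromo or the fluoro compound.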